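A few compounds are considered here, and "the series" means these few. Any claim that something is new, unique, unknown or untested is made for them only; others in the source may bear on it.

Working notes on the series. Compound 1 `CCCSc1nc(N/N=C(\C)c2ccccc2O)c2nnn(Cc3ccccc3Cl)c2n1` reaches only a limit in a functional assay on MCF7 cells (Homo sapiens) for antiproliferative activity, read by MTT assay, with a stated time of 72 h; a higher number here means a weaker inhibitor, a lower number a stronger inhibitor: for compound 1 the reading is > 64000 nM. Compound 2 `CCCSc1nc(N/N=C/c2cc(OC)c(OC)c(OC)c2)c2nnn(Cc3ccccc3)c2n1` likewise reaches only a limit in this assay, compound 2 giving > 64000 nM. Compound 3 `CCCSc1nc(N/N=C/c2ccc(N(C)C)cc2)c2nnn(Cc3ccccc3)c2n1` returns a number, with compound 3 at 12200 nM in this assay. Compound 1 thus sits at the limit of > 64000 nM in this assay, at which 2 of the 3 values shown sit, with no number of its own. Compound 4 `CCCSc1nc(N/N=C(\C)c2ccccc2O)c2nnn(Cc3ccccc3)c2n1` differs from compound 1 by hydrogen in place of chloro on an aromatic carbon. For the measured compounds named here, no step between measured compounds differing in one place is available, so no measured guide exists for this change. The expected step from compound 1 to compound 4 is a step that the limit leaves unreadable from compound 1 to compound 4, none beyond the usual scatter, most likely again a limit. Compound 4 is estimated at 70000 nM, within 30000 nM to 160000 nM.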

Compound 4, half-maximal inhibitory concentration: 11000 nM
Estimate against measurement, compound 4: 6.4-fold (0.80 log units) above; the whole stated range lies above it.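

Hydrogen in place of chloro on an aromatic carbon of the benzyl ring gives an at least 5.8-fold lower number from compound 1 to compound 4 (0.76 log units; beyond the scatter) in this assay, the only readable step shown, so this place on the 2-chlorobenzyl group affects the read-out. Going by these compounds, the true size of the step stays unknown because compound 1 stands at a limit: the limit of > 64000 nM in this assay, at which 2 of the 4 values shown sit.

Whether a group other than chloro at this place would also leave the reading at the limit remains open, as fluoro, methyl and methoxy are not among the compounds shown. On these data alone, whether the step carries over to other hydrazone parts also remains open.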